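Swapping the Aryl Group of Compound 3

A few compounds are considered here, and "the series" means these few. Any claim that something is new, unique, unknown or untested is made for them only; others in the source may bear on it.

compound 1 (`COc1cc(C(=O)c2sc(-c3ccccc3Cl)cc2N)cc(OC)c1OC`) gives 20 nM
compound 2 (`COc1cc(C(=O)c2sc(-c3ccc(Cl)c(Cl)c3)cc2N)cc(OC)c1OC`) gives 260 nM
compound 3 (`COc1cc(C(=O)c2sc(-c3ccc(F)cc3)cc2N)cc(OC)c1OC`) gives 20 nM

In a functional assay on L1210 cells (Mus musculus) for antiproliferative activity (on this read-out lower numbers stand for stronger inhibition and higher numbers for weaker inhibition), compound 3 stands level with compound 1 at the digits shown, and the two share the lowest of the three numbers, while compound 2 sits well above them. Compound 4 (`COc1cccc(-c2cc(N)c(C(=O)c3cc(OC)c(OC)c(OC)c3)s2)c1`) differs from compound 3 in one place (3-methoxyphenyl in place of 4-fluorophenyl on an aromatic carbon): 3-methoxyphenyl in place of 4-fluorophenyl on an aromatic carbon, next to the ring sulfur.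

All three measured steps change the group at this same place. One step (no change at the digits printed from compound 1 to compound 3 (within the scatter)) lies within the scatter, whereas another (a 13-fold higher number from compound 1 to compound 2 (1.11 log units; beyond the scatter)) is large, and the third (a 13-fold lower number from compound 2 to compound 3 (1.11 log units; beyond the scatter)) is equally large in the opposite direction. Within the data shown here, none of them introduces a 3-methoxyphenyl, so the data offer no direct precedent. Compound 2 at 260 nM is the only case of a large rise, so a modest move towards a higher number is expected, well short of that rise. The expected step is a 2.3-fold higher number from compound 3 to compound 4 (0.35 log units; beyond the scatter) in this estimate. Compound 4 is estimated at 45 nM with an expected range from 12 nM to 220 nM in this assay.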

Compound 4, half-maximal inhibitory concentration: 22 nM
Estimate against measurement, compound 4: 2.0-fold (0.31 log units) above; the range from low to high includes it.
By their numbers in this assay, from the lowest: compounds 1, 3 and 4 (each within the scatter of the next); then compound 2.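

In this assay, the 3-methoxyphenyl group of compound 4 holds the number set by the 4-fluorophenyl group (a 1.1-fold higher number from compound 3 to compound 4 (0.04 log units; within the scatter)) and by the 2-chlorophenyl group (a 1.1-fold higher number from compound 1 to compound 4 (0.04 log units; within the scatter)). At this position, next to the ring sulfur, a group that brings an oxygen and a hydrogen-bond acceptor therefore sits within the scatter of the two halogen-bearing groups. The 3,4-dichlorophenyl group now stands alone among the four (a 12-fold lower number from compound 2 to compound 4 (1.07 log units; beyond the scatter)), so the large rise of compound 2 does not follow from every change of aryl group here.

Nothing available explains why that one group stands apart. From the compounds shown here alone, whether an amine or a carboxylic acid on this aryl ring would hold the number as the methoxy group does remains open.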